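The compounds below may be only part of what the source reports. "The series", "measured", "known", "first", "only" and "open" are said of these compounds alone.

Measured so far in an assay for binding affinity to 5-hydroxytryptamine receptor 1F (Homo sapiens), read by radioligand binding; on this read-out higher numbers stand for weaker inhibition and lower numbers for stronger inhibition:
compound 1 `Cc1cccc(C(=O)Nc2ccc3[nH]cc(C4CCN(C)CC4)c3n2)c1` gives 5.8 nM
compound 2 `CN1CCC(c2c[nH]c3ccc(NC(=O)c4ccc(C#N)cc4)nc23)CC1` gives 7.2 nM
compound 3 `CN1CCC(c2c[nH]c3ccc(NC(=O)c4ccncc4)nc23)CC1` gives 8.4 nM

Compound 3 holds the highest of these three numbers, yet the steps of a 1.4-fold higher number from compound 1 to compound 3 (0.16 log units; within the scatter) and a 1.2-fold higher number from compound 2 to compound 3 (0.07 log units; within the scatter) both lie within the scatter, so the three compounds cannot be told apart on this read-out. Compound 4 `CN1CCC(c2c[nH]c3ccc(NC(=O)Nc4ccc(F)cc4)nc23)CC1` differs from compound 3 by one change: (4-fluorophenyl)amino in place of pyridin-4-yl on a carbonyl carbon. The measured steps all exchanged one aromatic ring for another on that carbonyl carbon, and each of them, including a 1.2-fold higher number from compound 1 to compound 2 (0.09 log units; within the scatter), stayed within the scatter. Among the measured compounds shown here, none of them added a nitrogen bearing a hydrogen between the carbonyl and the ring, so the new change has no direct precedent here. On that basis the step of a 1.2-fold higher number from compound 3 to compound 4 (0.08 log units; within the scatter) is expected to stay within the scatter, and compound 4 is estimated at 10 nM, within 3 nM to 35 nM.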

Compound 4, inhibition constant: 11 nM
Beside the measured number, compound 4's estimate is 1.1-fold (0.04 log units) below it; the range from low to high includes it.
By their numbers in this assay, from the lowest: compounds 1, 2, 3 and 4 (each within the scatter of the next).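

In this assay, among the compounds shown here, the position on the carbonyl carbon takes (4-fluorophenyl)amino, the first group here with a hydrogen-bond donor, as readily as it takes a ring attached directly: a 1.3-fold higher number from compound 3 to compound 4 (0.12 log units; within the scatter), a 1.5-fold higher number from compound 2 to compound 4 (0.18 log units; within the scatter) and a 1.9-fold higher number from compound 1 to compound 4 (0.28 log units; within the scatter). All four compounds therefore remain indistinguishable on this read-out, so adding the amino nitrogen has no measurable effect in this set. No supporting data bear on this result. From the compounds shown here alone, whether this tolerance extends to a carboxylic acid, a piperidine or a longer alkyl chain at this position remains open.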